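The compounds below may be only part of what the source reports. "The series", "measured", "known", "first", "only" and "open" are said of these compounds alone.

Measured so far:
Compound 1, `CC(C)(C)c1nc(NC(=O)CCCC(=O)O)ncc1-c1ccccc1`, gives 5%.
Compound 2, `Cc1nnc2c([n+]1[O-])CC(C(C)(C)C)CC2`, gives 48%.

In a functional assay on the whole organism for inhibition, with Rattus norvegicus as the target, with stated times of 1 h and 3.5 h, at a dose of 100 mg/kg by the oral route (a lower number here means less inhibition, a higher number more inhibition at the dose given (going by the name of the read-out)), compound 2 stands highest of the two numbers shown. Its nearest neighbour is compound 1, whose value lies lower by a gap that is beyond the usual scatter of this measurement. Within the data shown here, the two compounds share no single point of difference, so the data hold no step between measured compounds from which the effect of one change could be read.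

Compound 3, `CC(C)(C)C1CCc2nnc[n+]([O-])c2C1`, differs from compound 2 by hydrogen in place of methyl on an aromatic carbon. Among the measured compounds shown here, with no measured step of this kind to lean on, the expected change from compound 2 to compound 3 is small, in either direction, and not clearly beyond the scatter: the estimated step is a number 8 percentage points lower from compound 2 to compound 3 (within the scatter). Compound 3 is therefore expected to give about 40%, within a range from 15% to 65%.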

Compound 3, a percentage reported as inhibition, in the whole organism at one dose (the size of the read-out at that dose, not a potency): 36%
Compound 3: the middle estimate sits 4 percentage points above what was measured; low and high end bracket the measured number.
By their numbers in this assay, from the lowest: compound 1; then compound 3; then compound 2.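

Among these compounds, replacing methyl with hydrogen on the aromatic carbon between two ring nitrogen atoms gives the first step that can be read on its own: in this assay, the change produces a number 12 percentage points lower from compound 2 to compound 3 (beyond the scatter). The methyl is therefore not needed for inhibition at this dose, since compound 3 still gives 36%, but its removal does carry a modest cost. Nothing measured here accounts for the size of this step.

Among the compounds shown here, this single step gives only one comparison at this position, so it does not show whether the methyl's size or some other feature matters. From the compounds shown here alone, how an ethyl group, a longer chain or an amine on the same aromatic carbon would compare with methyl and hydrogen remains open.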